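The compounds below may be only part of what the source reports. "The series", "measured", "known", "first", "only" and "open" are said of these compounds alone.

Measured compounds in a functional assay on MCF7 cells (Homo sapiens) for cytotoxicity, read by MTT assay, with a stated time of 96 h; a lower number here means a stronger inhibitor, a higher number a weaker inhibitor:
compound 1 `COc1cc(C(=O)c2cn(-c3cccc(C)c3)cc2-c2cccc(N)c2)cc(OC)c1OC`, 130 nM
compound 2 `COc1cc(C(=O)c2cn(-c3cccc(C)c3)cc2-c2ccc(N)cc2)cc(OC)c1OC`, 18 nM
compound 3 `COc1cc(C(=O)c2cn(-c3cccc(N)c3)cc2-c2cccc(N)c2)cc(OC)c1OC`, 60 nM

Compound 4 `COc1cc(C(=O)c2cn(-c3cccc(N)c3)cc2-c2ccc(N)cc2)cc(OC)c1OC` is not yet measured. The change from compound 1 to compound 2 is 4-aminophenyl in place of 3-aminophenyl on an aromatic carbon, and it gave a 7.2-fold lower number from compound 1 to compound 2 (0.86 log units; beyond the scatter). The change from compound 3 to compound 4 is 4-aminophenyl in place of 3-aminophenyl on an aromatic carbon, the same kind of change, but its place differs: in compound 1 it sits two ring bonds from the ring atom that bears a 3-methylphenyl group, in compound 3 two ring bonds from the ring atom that bears a 3-aminophenyl group. The two cores differ by amino in place of methyl on an aromatic carbon, which gave a 2.2-fold lower number from compound 1 to compound 3 (0.34 log units; beyond the scatter). For compound 4 a step of similar size is expected, a 6.7-fold lower number from compound 3 to compound 4 (0.82 log units; beyond the scatter), because compound 1 to compound 2 showed a 7.2-fold lower number from compound 1 to compound 2 (0.86 log units; beyond the scatter) on a core differing only in that one group. Compound 4 is therefore estimated at 9 nM, with a likely range from 3 nM to 30 nM.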

Compound 4, half-maximal inhibitory concentration: 14 nM
Compound 4: middle estimate off by 1.6-fold (0.19 log units), on the low side, and the stated range covers the measured number.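

In this assay, 4-aminophenyl in place of 3-aminophenyl also lowers the number on the core carrying 3-aminophenyl, giving a 4.3-fold lower number from compound 3 to compound 4 (0.63 log units; beyond the scatter), and the step agrees with the one on the core carrying 3-methylphenyl: the same change on two cores in this assay, a 7.2-fold lower number (0.86 log units; beyond the scatter) from compound 1 to compound 2 and a 4.3-fold lower number (0.63 log units; beyond the scatter) from compound 3 to compound 4, 1.7-fold (0.23 log units) apart, within the scatter of two such steps. Amino in place of methyl gives a 1.3-fold lower number from compound 2 to compound 4 (0.11 log units; within the scatter), a step that cannot be told from scatter on its own yet does not differ from the earlier one: the same change on two cores in this assay, a 2.2-fold lower number (0.34 log units; beyond the scatter) from compound 1 to compound 3 and a 1.3-fold lower number (0.11 log units; within the scatter) from compound 2 to compound 4, 1.7-fold (0.23 log units) apart, within the scatter of two such steps. This supports carrying each change between these two cores only, and it shows neither how either change behaves on any other core nor why the steps arise.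

On these data alone, whether a dimethylamino or hydroxyl group in place of the amino group of 4-aminophenyl keeps the lower number remains open. The same holds for an acetamide in place of the amino group of 3-aminophenyl.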